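Adding a third methoxy group to an anti-inflammatory triazole

A few compounds are considered here, and "the series" means these few. Any claim that something is new, unique, unknown or untested is made for them only; others in the source may bear on it.

Measured compounds:
compound 1 `C=CCn1c(SC/C(=N\O)c2ccccc2)nnc1-c1ccc(OC)c(OC)c1`, 53%
compound 2 `C=CCn1c(SCC(=O)c2ccccc2)nnc1-c1ccc(OC)c(OC)c1`, 61%
compound 3 `C=CCn1c(SCC(=O)c2ccccc2)nnc1-c1ccc(OC)cc1`, 49%

All three were tested in a functional assay on the whole organism (strain albino) for inhibition, with Rattus norvegicus as the target, read by paw edema, with a stated time of 1 h, at a dose of 0.28 mmol/kg by the oral route; on this read-out higher numbers stand for more inhibition at the one dose given (going by the name of the read-out) and lower numbers for less inhibition. Among the measured compounds, compound 2 stands highest, but its lead over compound 1 is only a number 8 percentage points higher from compound 1 to compound 2 (within the scatter), so these two cannot be ranked against each other; only its distance to compound 3, a number 12 percentage points lower from compound 2 to compound 3 (beyond the scatter), is a real difference.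

The new compound is compound 4 `C=CCn1c(SCC(=O)c2ccccc2)nnc1-c1cc(OC)c(OC)c(OC)c1`. It differs from compound 2 by methoxy in place of hydrogen on an aromatic carbon, on an aromatic carbon of a six-membered aromatic ring of carbon only.

Within the data shown here, the step that bears on this is the one from compound 2 to compound 3, where a methoxy group was taken away and inhibition fell by a number 12 percentage points lower from compound 2 to compound 3 (beyond the scatter). Adding a methoxy group instead points the other way, so for compound 4 a modest rise in this assay, or a change within the scatter, is expected. The estimate for compound 4 is 65%, between 52% and 78%, meaning an expected step of a number 4 percentage points higher from compound 2 to compound 4 (within the scatter).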

Compound 4, a percentage reported as inhibition, in the whole organism at one dose (the size of the read-out at that dose, not a potency): 49%
Estimate against measurement, compound 4: 16 percentage points above; measured number outside the range, below it.
By their numbers in this assay, from the lowest: compounds 3, 4, 1 and 2 (each within the scatter of the next, the first and the last beyond it).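

In this assay, a methoxy group on the aromatic carbon ortho to a methoxy group and meta to a large group does not extend the earlier trend; instead the change gives a number 12 percentage points lower from compound 2 to compound 4 (beyond the scatter). Taking a methoxy group away had also cost inhibition, with a number 12 percentage points lower from compound 2 to compound 3 (beyond the scatter), so both changes made to the methoxy groups of compound 2 lead downward. More methoxy groups on this aromatic ring therefore do not simply mean more inhibition, and this position does not take the added group without a loss at the one dose given.

No measurement at hand accounts for this drop. Still open, on these data alone, is how a different group at this position, such as a hydroxyl group, a fluorine atom or a longer chain like ethoxy, would compare with the hydrogen of compound 2.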